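Methyl on the benzyl ring of an amide-sulfonamide series

The source may report more compounds than this note shows. Statements on the series, on what has been measured and on what is new or still open speak of the compounds shown alone.

Three measured compounds share one core and differ only in the bicyclic group on the sulfonyl sulfur. In a functional assay on CHO cells for positive allosteric modulation of muscarinic acetylcholine receptor M5 (Homo sapiens), read by calcium flux (a higher number here means a larger maximal response, a lower number a smaller maximal response), compound 1 `CCN(Cc1ccccc1)C(=O)C1CCN(S(=O)(=O)c2ccc3occc3c2)CC1` gives 80%, compound 2 `CCN(Cc1ccccc1)C(=O)C1CCN(S(=O)(=O)c2ccc3cn[nH]c3c2)CC1` gives 86%, and compound 3 `CCN(Cc1ccccc1)C(=O)C1CCN(S(=O)(=O)c2ccc3nsnc3c2)CC1` gives 81%. All three numbers sit within the scatter of one another: a number 6 percentage points higher from compound 1 to compound 2 (within the scatter), a number 1 percentage points higher from compound 1 to compound 3 (within the scatter), a number 5 percentage points lower from compound 2 to compound 3 (within the scatter). Compound 2 therefore stands apart from neither neighbour by more than the assay's noise, and the three bicyclic groups on the sulfonyl sulfur read as interchangeable in this assay.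

Compound 4 `CCN(Cc1ccccc1C)C(=O)C1CCN(S(=O)(=O)c2ccc3cn[nH]c3c2)CC1` is the next member. Against compound 2 the change is methyl in place of hydrogen on an aromatic carbon, that is, benzyl to 2-methylbenzyl on the amide nitrogen side of the core. Among the measured compounds shown here, none of the measured steps touches this part of the molecule; every step so far is on the sulfonyl sulfur, and each was within the scatter. There is thus no measured step that bears directly on a methyl entering the benzyl ring, and the series as a whole has shown no move beyond the scatter in this assay.

The expectation for compound 4 is a maximal response close to that of compound 2, with a step of a number 2 percentage points lower from compound 2 to compound 4 (within the scatter) expected, none beyond the scatter. Compound 4 is estimated at 84%, with a range from 70% to 98%.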

Compound 4, largest response reached (reported as percent of maximum), in percent of the reference or control that the assay uses: 103%
For compound 4 the middle estimate is 19 percentage points below the measured one; the whole stated range lies below it.
By their numbers in this assay, from the lowest: compounds 1, 3 and 2 (each within the scatter of the next); then compound 4.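

The benzyl ring on the amide nitrogen side of the shared core is the only place shown so far where this assay moves beyond the scatter: methyl in place of hydrogen on an aromatic carbon, ortho to a large group, gives a number 17 percentage points higher from compound 2 to compound 4 (beyond the scatter) in the series. The exchanges of bicyclic group on the sulfonyl sulfur all stayed within the scatter, so this position, unlike that one, separates compounds in this read-out, and a change of a single carbon, benzyl to 2-methylbenzyl, is enough to do it. Nothing among the available data bears on why the methyl has this effect, and the step stands as an observation only.

The compounds shown leave open whether the step carries over to the 1-benzofuran-5-yl group of compound 1 or the other bicyclic group of compound 3, since the 2-methylbenzyl group appears here with the 1H-indazol-6-yl group alone. They also leave open whether an ethyl, a methoxy or a chlorine in place of the methyl would give a similar response, and whether the methyl elsewhere on the ring would do the same.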